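The source may report more compounds than this note shows. Statements on the series, on what has been measured and on what is new or still open speak of the compounds shown alone.

In an assay on isolated protein for inhibition of Amine oxidase [copper-containing] 3 (Homo sapiens), read by Amplex Red (a higher number here means a weaker inhibitor, a lower number a stronger inhibitor), compound 3 `CC(C)(C)c1ccc(OC/C(F)=C\CN)cc1` gives 210 nM, the lowest of the three numbers in hand. Compound 2 `NC/C=C(/F)COc1ccc(Oc2ccccc2)cc1` gives 240 nM in this assay, a number that lies within the scatter of compound 3, so the two cannot be told apart. Compound 1 `NC/C=C/COc1ccccc1` gives 82000 nM in this assay, far beyond the scatter from both of the others. Compound 4 `NC/C=C(/F)COc1ccc(C(N)=O)cc1` has not yet been measured in this assay. It differs from compound 3 in one place: carbamoyl in place of tert-butyl on an aromatic carbon. Within the data shown here, no pair of measured compounds shows this kind of exchange, so the data hold no step that isolates it. What they do show is that compound 2 and compound 3 differ in one group yet give numbers within the scatter of each other. On that basis the step from compound 3 to compound 4 is expected to be modest, a 2.9-fold higher number from compound 3 to compound 4 (0.46 log units; beyond the scatter), leaning toward a higher number but with no firm ground for a large shift. Compound 4 is accordingly estimated at 600 nM, with a range from 150 nM to 2500 nM.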

Compound 4, half-maximal inhibitory concentration: 1070 nM
Estimate against measurement, compound 4: 1.8-fold (0.25 log units) below, and the stated range covers the measured number.
By their numbers in this assay, from the lowest: compounds 3 and 2 (each within the scatter of the next); then compound 4; then compound 1.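

Among these compounds, the exchange of tert-butyl for carbamoyl on an aromatic carbon gives a 5.1-fold higher number from compound 3 to compound 4 (0.71 log units; beyond the scatter) in this assay and is the first step here that isolates a change at this place. It shows that the place does not treat all groups alike: the number moves beyond the scatter when a group with no hydrogen-bond donor or acceptor gives way to one that has both, though the step is modest and rests on this single pair. The data offer nothing that accounts for the step.

From the compounds shown here alone, whether the shift follows the carbamoyl group itself or the loss of the tert-butyl group stays open. A methyl ester, a nitrile, an isopropyl group, a carboxylic acid or an amine at the same aromatic carbon does not appear among the compounds shown, so the reach of this one step remains unknown.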